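Trifluoromethyl in place of bromo: a small step expected

This account rests on a few compounds, and the source may have more. Where it says the series, first, only, none or still open, it means among the compounds named here.

Measured so far in a functional assay on ECa-109 cells for inhibition, with ECa-109 cell line (Homo sapiens) as the target, read by sulforhodamine B assay; a higher number here means a weaker inhibitor, a lower number a stronger inhibitor:
compound 1 `CCCc1ccc(NC2=CC(=O)c3nc4n(c3C2=O)[C@H]2OC[C@@H](O)[C@H]2OC4)cc1` gives > 4000 nM here
compound 2 `CCc1ccc(NC2=CC(=O)c3nc4n(c3C2=O)[C@H]2OC[C@@H](O)[C@H]2OC4)cc1` gives 3080 nM here
compound 3 `O=C1C=C(Nc2ccc(Br)cc2)C(=O)c2c1nc1n2[C@H]2OC[C@@H](O)[C@H]2OC1` gives 2850 nM here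

The reading for compound 1 is a limit and not a number. Compound 3 stands level with compound 2 within the scatter, as shown by a 1.1-fold lower number from compound 2 to compound 3 (0.03 log units; within the scatter) in this series. Compound 4 `O=C1C=C(Nc2ccc(C(F)(F)F)cc2)C(=O)c2c1nc1n2[C@H]2OC[C@@H](O)[C@H]2OC1` carries trifluoromethyl in place of bromo on an aromatic carbon para to a large group. The nearest measured swap at this place is a 1.1-fold lower number from compound 2 to compound 3 (0.03 log units; within the scatter), while an at least 1.4-fold lower number from compound 1 to compound 3 (0.14 log units; that floor lies within the scatter) gives only a floor. Because a 1.1-fold lower number from compound 2 to compound 3 (0.03 log units; within the scatter) stays within the scatter, no step beyond the scatter is expected in this assay. The expected step is a 1.1-fold lower number from compound 3 to compound 4 (0.02 log units; within the scatter) in size. For compound 4 the estimated value is 2700 nM with an expected range of 1300 nM to 4000 nM as its ends.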

Compound 4, half-maximal inhibitory concentration: 5500 nM
The estimate for compound 4 lay 2.0-fold (0.31 log units) below the measured number; measured number above the stated range.
By their numbers in this assay, from the lowest: compounds 3, 2 and 4 (each within the scatter of the next).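

In this assay, trifluoromethyl on this aromatic carbon gives a 1.9-fold higher number from compound 3 to compound 4 (0.29 log units; within the scatter), and the swap from ethyl gives a 1.8-fold higher number from compound 2 to compound 4 (0.25 log units; within the scatter). Even with this larger group entering, every readable step at this position stays within the scatter, so the position has yet to show a real difference. The step from compound 1 to compound 4 cannot be read, because the reading for compound 1 is a limit: the limit of > 4000 nM in this assay, at which 1 of the 4 values shown sits.

Going by these compounds, whether an amine, a carboxylic acid or a methoxy group at this position would produce a step beyond the scatter remains open. So does the effect of any change elsewhere on the shared core.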